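Swapping the Nitrophenyl for a Methylphenyl on the Cyanoguanidine

This account rests on a few compounds, and the source may have more. Where it says the series, first, only, none or still open, it means among the compounds named here.

Of the compounds shown here, three sharing one core have been tested in a functional assay (aorta) with Rattus norvegicus as the target; on this read-out lower numbers stand for stronger inhibition and higher numbers for weaker inhibition. Compound 1 `CC1(C)Oc2ccc(C#N)cc2[C@@H](NC(=O)Nc2ccccc2)[C@@H]1O` gives 800 nM, compound 2 `CC1(C)Oc2ccc(C#N)cc2[C@@H](NC(=O)Nc2ccccn2)[C@@H]1O` gives 440 nM, and compound 3 `CC1(C)Oc2ccc(C#N)cc2[C@@H](/N=C(\NC#N)Nc2ccc([N+](=O)[O-])cc2)[C@@H]1O` gives 300 nM, the lowest of the three numbers, although its gap to compound 2 is within the scatter and only its gap to compound 1 lies beyond it. Compound 4 `Cc1cccc(N/C(=N/[C@@H]2c3cc(C#N)ccc3OC(C)(C)[C@H]2O)NC#N)c1` differs from compound 3 in one place: 3-methylphenyl in place of 4-nitrophenyl on an amine nitrogen. Going by the values given here, the only measured step, a 1.8-fold lower number from compound 1 to compound 2 (0.26 log units; within the scatter), swaps a ring on a different kind of nitrogen and stays within the scatter, so it bears on this change only loosely. Among the compounds with values here, no measured step probes the nitro group or the methyl group. The expected step is therefore a 1.7-fold higher number from compound 3 to compound 4 (0.22 log units; within the scatter), a small one. Compound 4 is estimated at 500 nM, within a range from 150 nM to 1500 nM.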

Compound 4, half-maximal inhibitory concentration: 1000 nM
Beside the measured number, compound 4's estimate is 2.0-fold (0.30 log units) below it; the measured number falls inside the stated range.
By their numbers in this assay, from the lowest: compounds 3, 2, 1 and 4 (each within the scatter of the next, the first and the last beyond it).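

Changing the ring on this amine nitrogen from 4-nitrophenyl to 3-methylphenyl gives a 3.3-fold higher number from compound 3 to compound 4 (0.52 log units; beyond the scatter). Going by these compounds alone, the earlier ring swap, on an amide-type nitrogen, stayed within the scatter, so this is the first ring change here to give a clear difference. No measured evidence explains the step.

The change alters both the group on the ring and its place, so the two effects remain tangled. A 4-methylphenyl or a 3-nitrophenyl on this nitrogen would separate them.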